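Aryl replacement of the propargyl alcohol in compound 1

This account rests on a few compounds, and the source may have more. Where it says the series, first, only, none or still open, it means among the compounds named here.

Compound 1 `Nc1ccc(S(=O)(=O)N2CCN(c3ncc(C(O)(C(F)(F)F)C(F)(F)F)cc3C#CCO)CC2)cn1` carries a 3-hydroxyprop-1-yn-1-yl group on the shared core. In an ADME assay (liver) for metabolic stability, with Liver microsome (Rattus norvegicus) as the target, using microsomes and NADPH, with a stated time of 30 min, tested at 1 uM (on this read-out higher numbers stand for fast clearance and lower numbers for slow clearance), compound 1 gives 65 mL.min-1.g-1, the second highest of the three numbers measured. Compound 2 `CC(C)(O)C#Cc1cc(C(O)(C(F)(F)F)C(F)(F)F)cnc1N1CCN(S(=O)(=O)c2ccc(N)nc2)CC1` gives 16 mL.min-1.g-1, and a 4.1-fold lower number from compound 1 to compound 2 (0.61 log units; beyond the scatter). Compound 3 `CC(C)(C)n1cc(-c2cc(C(O)(C(F)(F)F)C(F)(F)F)cnc2N2CCN(S(=O)(=O)c3ccc(N)nc3)CC2)cn1` gives 459 mL.min-1.g-1, and a 7.1-fold higher number from compound 1 to compound 3 (0.85 log units; beyond the scatter); between the two alkyne compounds and the aryl compound, a 29-fold higher number from compound 2 to compound 3 (1.46 log units; beyond the scatter).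

Compound 4 `CS(=O)(=O)Nc1cccc(-c2cc(C(O)(C(F)(F)F)C(F)(F)F)cnc2N2CCN(S(=O)(=O)c3ccc(N)nc3)CC2)c1` is the next analogue. The change from compound 1 is 3-(methanesulfonamido)phenyl in place of 3-hydroxyprop-1-yn-1-yl on an aromatic carbon. Going by the values given here, the step that bears on it is the one from compound 1 to compound 3, where an aromatic ring also replaced the 3-hydroxyprop-1-yn-1-yl group on the same aromatic carbon and clearance rose beyond the scatter. The entering 3-(methanesulfonamido)phenyl group is not the same as the 1-(tert-butyl)-1H-pyrazol-4-yl group of compound 3, so the same size of rise is not assured, but a rise is expected. For compound 4 the expected step is a 3.1-fold higher number from compound 1 to compound 4 (0.49 log units; beyond the scatter), and the estimated value is 200 mL.min-1.g-1, with a range from 80 mL.min-1.g-1 to 500 mL.min-1.g-1.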

Compound 4, intrinsic clearance in microsomes: 81 mL.min-1.g-1
Compound 4: middle estimate off by 2.5-fold (0.39 log units), on the high side; the range from low to high includes it.
By their numbers in this assay, from the lowest: compound 2; then compounds 1 and 4 (each within the scatter of the next); then compound 3.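

An aromatic ring on this aromatic carbon does not by itself bring the rise seen with compound 3: 3-(methanesulfonamido)phenyl in place of 3-hydroxyprop-1-yn-1-yl gives a 1.2-fold higher number from compound 1 to compound 4 (0.10 log units; within the scatter) in this assay. The identity of the aromatic group therefore matters here, since the step between the two aryl compounds is a 5.7-fold lower number from compound 3 to compound 4 (0.75 log units; beyond the scatter). The 3-hydroxy-3-methylbut-1-yn-1-yl group of compound 2 still gives the lowest number of the four, with a 5.1-fold higher number from compound 2 to compound 4 (0.70 log units; beyond the scatter).

No supporting data on hand account for these differences. As far as these compounds go, whether the methanesulfonamido group or the phenyl ring sets the number for compound 4 stays open, and a phenyl ring carrying an amine or a carboxylic acid in its place would bear on that question.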